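Trimming the methoxy pattern on the cinnamamide side

The compounds below may be only part of what the source reports. "The series", "measured", "known", "first", "only" and "open" are said of these compounds alone.

This series shares a core in which a cinnamamide is attached to an aniline ring. Compound 2 `COc1ccc(C(=O)c2cc(OC)c(OC)c(OC)c2)cc1NC(=O)/C=C/c1cc(OC)c(OC)c(OC)c1` carries a 3,4,5-trimethoxyphenyl on the double-bonded chain carbon, and in a functional assay on ME-180 cells (Homo sapiens) for cytotoxicity, read by MTT assay, with a stated time of 72 h (a higher number here means a weaker inhibitor, a lower number a stronger inhibitor), compound 2 gives 2100 nM, the lowest number among the three measured compounds. Compound 3 `COc1ccc(/C=C/C(=O)Nc2cc(C(=O)c3cc(OC)c(OC)c(OC)c3)ccc2OC)cc1` carries a 4-methoxyphenyl in the same place and gives 11800 nM; compound 1 `COc1cccc(/C=C/C(=O)Nc2cc(OC)c(OC)c(OC)c2)c1`, which lacks the trimethoxybenzoyl portion altogether, gives 17300 nM.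

Compound 4 `COc1cccc(/C=C/C(=O)Nc2cc(C(=O)c3cc(OC)c(OC)c(OC)c3)ccc2OC)c1` differs from compound 2 in one place: 3-methoxyphenyl in place of 3,4,5-trimethoxyphenyl on a double-bonded chain carbon bound to a double-bonded chain carbon. Within the data shown here, the only measured step that speaks to this change is a 5.6-fold higher number from compound 2 to compound 3 (0.75 log units; beyond the scatter), where stripping the trimethoxyphenyl down to a single methoxy left a clearly weaker inhibitor. Among the measured compounds shown here, compound 1, with the same 3-methoxyphenyl but on a simpler core, sits at the weak end of the set as well, though no single-change step links it to compound 4.

Removing two of the three methoxy groups is therefore expected to cost potency, and the expected step is a 4.8-fold higher number from compound 2 to compound 4 (0.68 log units; beyond the scatter). Compound 4 is estimated to give 10000 nM in this assay, with a plausible range from 4000 nM to 25000 nM.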

Compound 4, half-maximal inhibitory concentration: 4300 nM
Estimate against measurement, compound 4: 2.3-fold (0.37 log units) above; the measured number falls inside the stated range.
By their numbers in this assay, from the lowest: compound 2; then compound 4; then compounds 3 and 1 (each within the scatter of the next).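

On this double-bonded chain carbon, where the methoxy group sits matters, and not only how many methoxy groups the ring carries: in this assay, 3-methoxyphenyl in place of 4-methoxyphenyl brings a 2.7-fold lower number from compound 3 to compound 4 (0.44 log units; beyond the scatter). Cutting the 3,4,5-trimethoxyphenyl down to 3-methoxyphenyl still costs some potency, with a 2.0-fold higher number from compound 2 to compound 4 (0.31 log units; beyond the scatter), but this loss is smaller than the one seen with 4-methoxyphenyl, which shows a 5.6-fold higher number from compound 2 to compound 3 (0.75 log units; beyond the scatter). Among the three groups compared on this core, 3,4,5-trimethoxyphenyl therefore still gives the lowest number, but 3-methoxyphenyl alone recovers a good part of the gap that 4-methoxyphenyl had opened.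

Nothing available gives a reason for the difference between the two methoxy placements. On these data alone, it also remains open whether a plain phenyl would do worse than 3-methoxyphenyl, and whether 3,5-dimethoxyphenyl would close the remaining gap to compound 2 or a 3-hydroxyphenyl or 3-aminophenyl could stand in for the methoxy group at this place.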